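Piperidine nitrogen substituent: acid amide to hydroxyalkyl

This account rests on a few compounds, and the source may have more. Where it says the series, first, only, none or still open, it means among the compounds named here.

Two compounds of the series share the core shown in compound 1 `O=S(=O)(NC1CCN(S(=O)(=O)c2ccccc2)CC1)c1cc(S(=O)(=O)c2ccccc2)ccc1C(F)(F)F` and differ only at the amine nitrogen in the ring. In an assay on isolated protein for displacement of a labelled ligand from secreted frizzled-related protein 1 (Homo sapiens), read by fluorescence polarization, with a stated time of 30 min (a higher number here means a weaker inhibitor, a lower number a stronger inhibitor), compound 1 gives 130 nM. Going by the values given here, compound 2 `O=C(O)CCCC(=O)N1CCC(NS(=O)(=O)c2cc(S(=O)(=O)c3ccccc3)ccc2C(F)(F)F)CC1` gives 500 nM in this assay, the highest of the two numbers; the only step, a 3.8-fold higher number from compound 1 to compound 2 (0.59 log units; beyond the scatter), went beyond the scatter. Compound 3 `CC(C)(O)CCN1CCC(NS(=O)(=O)c2cc(S(=O)(=O)c3ccccc3)ccc2C(F)(F)F)CC1` carries the change (3-hydroxy-3-methylbutyl in place of (3-carboxypropyl)carbonyl on an amine nitrogen in a ring). Among the compounds with values here, no measured step covers a hydroxyalkyl group at this nitrogen, and the one step present concerns a different pair of groups, so it bears on the present change only loosely, showing that this position tolerates exchange with a modest shift. The step of a 1.3-fold lower number from compound 2 to compound 3 (0.10 log units; within the scatter) is expected to stay within the scatter. Compound 3 is estimated at 400 nM in this assay, with a range from 130 nM to 1300 nM.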

Compound 3, half-maximal inhibitory concentration: 200 nM
Beside the measured number, compound 3's estimate is 2.0-fold (0.30 log units) above it; low and high end bracket the measured number.
By their numbers in this assay, from the lowest: compounds 1 and 3 (each within the scatter of the next); then compound 2.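

In this assay the 3-hydroxy-3-methylbutyl group improves on the (3-carboxypropyl)carbonyl group, with a 2.5-fold lower number from compound 2 to compound 3 (0.40 log units; beyond the scatter) beyond the scatter. Against the phenylsulfonyl group the same chain gives a 1.5-fold higher number from compound 1 to compound 3 (0.19 log units; within the scatter) within the scatter, so on this amine nitrogen in a ring, a substituent with no ring and no double bond outside aromatic rings matches the phenylsulfonyl group within the scatter. Nothing available explains either step.

The compounds shown leave open whether the tertiary hydroxyl itself contributes, a question that a plain 3-methylbutyl chain would address. Also open, going by these compounds, is how an amine or a carboxylic acid at the end of a similar alkyl chain, with no carbonyl on the ring nitrogen, would compare with compound 3.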